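Sulfonyl substituent exchange on the shared core

The source may report more compounds than this note shows. Statements on the series, on what has been measured and on what is new or still open speak of the compounds shown alone.

Measured so far:
compound 1 `CCN(CC)c1ccc2cc(C(=O)c3ccc(N4CCN(C(=O)CN5CCN(C(=O)CCl)CC5)CC4)cc3)oc2c1` gives 5520 nM
compound 2 `CCN(CC)c1ccc2cc(C(=O)c3ccc(N4CCN(C(=O)CN5CCN(S(=O)(=O)C6CC6)CC5)CC4)cc3)oc2c1` gives 28100 nM

In a functional assay on HeLa cells (Homo sapiens) for cytotoxicity, read by MTT assay, with a stated time of 48 h (on this read-out higher numbers stand for weaker inhibition and lower numbers for stronger inhibition), compound 2 gives 28100 nM, the highest of the two numbers; its nearest neighbour is compound 1, and the step of a 5.1-fold higher number from compound 1 to compound 2 (0.71 log units; beyond the scatter) lies beyond the scatter. Among the compounds with values here, the one measured step replaced (chloromethyl)carbonyl with cyclopropylsulfonyl on the amine nitrogen in the ring; it does not touch the sulfonyl substituent itself.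

Compound 3 `CCN(CC)c1ccc2cc(C(=O)c3ccc(N4CCN(C(=O)CN5CCN(S(=O)(=O)c6ccc(OC(F)(F)F)cc6)CC5)CC4)cc3)oc2c1` differs from compound 2 by 4-(trifluoromethoxy)phenyl in place of cyclopropyl on a sulfonyl sulfur. Within the data shown here, no measured step in this assay concerns an exchange of the group on the sulfonyl sulfur, so nothing seen here fixes the direction. With the sulfonamide kept and only its substituent changed, compound 3 is expected to sit near compound 2, the step of a 1.3-fold lower number from compound 2 to compound 3 (0.11 log units; within the scatter) expected to stay within the scatter. For compound 3 the estimate is 22000 nM, in the range 7000 nM to 70000 nM.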

Compound 3, half-maximal inhibitory concentration: 30200 nM
Beside the measured number, compound 3's estimate is 1.4-fold (0.14 log units) below it; the range from low to high includes it.
By their numbers in this assay, from the lowest: compound 1; then compounds 2 and 3 (each within the scatter of the next).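

In this assay, within the data shown here, this is the first step that reads an exchange of the group on the sulfonyl sulfur: a 1.1-fold higher number from compound 2 to compound 3 (0.03 log units; within the scatter), with 4-(trifluoromethoxy)phenyl in place of cyclopropyl. Going from a three-membered non-aromatic carbon ring with 3 heavy atoms to a six-membered aromatic ring with 11 heavy atoms thus leaves the read-out within the scatter, for this one pair. No supporting data bear on why these two groups read alike.

From the compounds shown here alone, whether other groups on the sulfonyl sulfur would also stay within the scatter remains open, for example a methyl, a longer alkyl chain, or a phenyl carrying an amine or a carboxylic acid. Also open, going by these compounds, is whether a 5.1-fold higher number from compound 1 to compound 2 (0.71 log units; beyond the scatter) reflects the loss of (chloromethyl)carbonyl specifically, since a single step cannot separate that from the entry of cyclopropylsulfonyl.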